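A few compounds are considered here, and "the series" means these few. Any claim that something is new, unique, unknown or untested is made for them only; others in the source may bear on it.

Working notes on the shared core in a functional assay on MDA-MB-231 cells (Homo sapiens) for inhibition, read by MTT assay, with a stated time of 72 h, tested at 20 uM; a higher number here means more inhibition at the concentration tested (going by the name of the read-out), a lower number less inhibition. Compound 1 `CN(c1ccc(Oc2ncnc3sccc23)cc1)c1nccc(N2CCc3ccccc3C2)n1` gives 24.3%. Compound 2 `CN(c1ccc(Oc2ncnc3sccc23)cc1)c1nccc(N2CCCCC2)n1` gives 29.3%. Compound 3 `c1cc(N2CCCC2)nc(Nc2ccc(Oc3ncnc4sccc34)cc2)n1` gives 24.7%. Compound 3 stands nearest to compound 1 and furthest from compound 2, and both gaps lie within the usual scatter, so the three numbers cannot be separated. Among the compounds with values here, the only measured step between compounds differing in one place is a number 5 percentage points higher from compound 1 to compound 2 (within the scatter), also within the scatter.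

Compound 4 `CN(c1ccc(Oc2ncnc3sccc23)cc1)c1nccc(N2CCCC2)n1` is not yet measured. It differs from compound 3 by methyl in place of hydrogen on a nitrogen on an aromatic ring. Within the data shown here, no measured step bears directly on this change: compounds 1 and 2 carry the methyl and compound 3 does not, but each of them also differs from compound 3 in the ring on the aromatic carbon, so only their values can be compared, and those values sit together. Since every measured number here lies within the scatter of every other, the change is expected to give a number 1.3 percentage points higher from compound 3 to compound 4 (within the scatter), no movement beyond the scatter. Compound 4 is estimated at 26%, with a range from 13% to 39%.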

Compound 4, a percentage reported as inhibition, at one concentration (the size of the read-out at that concentration, not a potency): 31%
Beside the measured number, compound 4's estimate is 5 percentage points below it; the range from low to high includes it.
By their numbers in this assay, from the lowest: compounds 1, 3, 2 and 4 (each within the scatter of the next).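

In this assay, methyl in place of hydrogen on a nitrogen on an aromatic ring can now be read directly, as a number 6.3 percentage points higher from compound 3 to compound 4 (within the scatter), so this change does not separate from the scatter with the pyrrolidin-1-yl group held fixed. With the methyl also held fixed, pyrrolidin-1-yl in place of piperidin-1-yl gives a number 1.7 percentage points higher from compound 2 to compound 4 (within the scatter), and pyrrolidin-1-yl in place of 1,2,3,4-tetrahydroisoquinolin-2-yl gives a number 6.7 percentage points higher from compound 1 to compound 4 (within the scatter), so no two of these three rings on the aromatic carbon can be told apart. No supporting evidence bears on these steps.

From the compounds shown here alone, whether a morpholine ring or an open-chain amine on the aromatic carbon would move the number beyond the scatter remains open. The same holds for an ethyl group or a longer chain on the nitrogen.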